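The source may hold more compounds than are shown below. What is called first, only, known or untested is meant among the compounds shown, and "the series" means these compounds.

Of the compounds shown here, two have numbers so far. Compound 1 `COc1ccc2c(c1OC)CC[C@H]2NCCCCc1cn(-c2ccc(F)cc2)c2ccccc12` gives 175 nM in an assay on membranes from brain for displacement of a labelled ligand from Sigma non-opioid intracellular receptor 1 (Cavia porcellus), read by radioligand binding; a lower number here means a stronger inhibitor, a higher number a weaker inhibitor. Compound 2 `CCN(CCCCc1cn(-c2ccc(F)cc2)c2ccccc12)C1CCc2c1ccc(OC)c2OC`, the ethyl-bearing analogue, gives 59.2 nM in this assay, the lowest of the two numbers; compound 1 sits a clear step higher, beyond the scatter. Compound 3 `COc1ccc2c(c1OC)CCC2NCCCCc1cn(-c2ccc(F)cc2)c2ccccc12` is not yet measured. It differs from compound 2 in one place: hydrogen in place of ethyl on an amine nitrogen. Among the measured compounds shown here, no measured pair isolates this change, so its size is not known from the numbers here. Compound 1, which also carries hydrogen on the amine nitrogen, gives 175 nM in this assay, so the step is expected to run upward, toward weaker inhibition, and to exceed the scatter. The estimate for compound 3 in this assay is 160 nM with a range of 60 nM to 450 nM. The step of a 2.7-fold higher number from compound 2 to compound 3 (0.43 log units; beyond the scatter) is the expected size of this change.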

Compound 3, inhibition constant: 215 nM
Beside the measured number, compound 3's estimate is 1.3-fold (0.13 log units) below it, within the range that was stated.
By their numbers in this assay, from the lowest: compound 2; then compounds 1 and 3 (each within the scatter of the next).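

The change of ethyl to hydrogen on the amine nitrogen now has a directly measured size in this assay: a 3.6-fold higher number from compound 2 to compound 3 (0.56 log units; beyond the scatter). This places the ethyl-bearing compound clearly apart from the hydrogen-bearing one at this nitrogen, a contrast that rests on this single pair. At the saturated ring carbon, a 1.2-fold higher number from compound 1 to compound 3 (0.09 log units; within the scatter), so this assay does not separate the form drawn R from the form drawn without a configuration, and the only difference in that pair is: the fact that one of compounds 1 and 3 is drawn with a defined configuration and the other without, at the place where they differ

On these data alone, how a methyl, a propyl or a longer chain on the amine nitrogen would compare with ethyl remains open. Also open, as far as these compounds go, is what the S configuration at the saturated ring carbon would give, with hydrogen or with ethyl on the nitrogen.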